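This account rests on a few compounds, and the source may have more. Where it says the series, first, only, none or still open, it means among the compounds named here.

Working notes on the series. In a functional assay on MCF7 cells (Homo sapiens) for inhibition, read by CCK-8 assay, with a stated time of 48 h (on this read-out lower numbers stand for stronger inhibition and higher numbers for weaker inhibition), compound 1 `Cn1ccc2cc(-c3cc4nccc(-c5ccc(F)cc5)n4n3)ccc21` gives 4580 nM. Compound 2 `COc1cc(-c2ccnc3cc(-c4ccc(-c5cnn(C)c5)cc4)nn23)cc(OC)c1OC` gives 274 nM in this assay, and compound 3 `COc1cc(-c2ccnc3cc(-c4ccccc4)nn23)cc(OC)c1OC` gives 254 nM in this assay. For the measured compounds named here, the only single-site step measured so far, a 1.1-fold lower number from compound 2 to compound 3 (0.03 log units; within the scatter), puts hydrogen in place of 1-methyl-1H-pyrazol-4-yl on an aromatic carbon and leaves the number essentially unchanged. Compound 3 thus holds the lowest of the three numbers, with compound 2 within the scatter of it and compound 1, built on a different core, standing well apart.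

Compound 4 `COc1cc(-c2ccnc3cc(-c4cccc(C#N)c4)nn23)cc(OC)c1OC` is not yet measured. It differs from compound 3 by cyano in place of hydrogen on an aromatic carbon, the change sitting on an aromatic carbon of a six-membered aromatic ring of carbon only, meta to a large group. Going by the values given here, no measured step adds a cyano group anywhere, so nothing speaks directly to this substituent. Among the compounds with values here, the one step that does concern substitution of the same phenyl ring, a 1.1-fold lower number from compound 2 to compound 3 (0.03 log units; within the scatter), shows that removing a large group from that ring made no difference beyond the scatter. On that basis the step from compound 3 to compound 4 is expected to be small, a 1.0-fold lower number from compound 3 to compound 4 (0.01 log units; within the scatter), with no clear direction. Compound 4 is therefore estimated at 250 nM, with a range from 100 nM to 650 nM.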

Compound 4, half-maximal inhibitory concentration: > 10000 nM
Compound 4 ended at the assay's limit; the forecaster's own chance of this, stated with the estimate: 5%; middle value at least 40-fold (1.60 log units) from the limit.
By their numbers in this assay, from the lowest: compounds 3 and 2 (each within the scatter of the next); then compound 1. At a limit, above all of these: compound 4.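

Cyano in place of hydrogen on an aromatic carbon, meta to a large group, brings the first change beyond the scatter on this phenyl ring of the shared core, with an at least 39-fold higher number from compound 3 to compound 4 (1.59 log units; beyond the scatter) in this assay. The other single-site step on this ring, a 1.1-fold lower number from compound 2 to compound 3 (0.03 log units; within the scatter), stayed within the scatter, so the tolerance it showed for the loss of a large group does not extend to the change from phenyl to 3-cyanophenyl. The value of compound 4, > 10000 nM, is a limit of the assay and not a number: the limit of > 10000 nM in this assay, at which 1 of the 4 values shown sits.

The compounds shown leave open whether the sharp rise belongs to cyano itself or to any substituent on this carbon, as a methoxy group, an amine or a carboxylic acid at the same place would help to tell. They also leave open whether cyano on another carbon of the same phenyl ring gives a similar result, and the data here offer no cause for the step.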